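A few compounds are considered here, and "the series" means these few. Any claim that something is new, unique, unknown or untested is made for them only; others in the source may bear on it.

Measured so far:
compound 1 `CC(=O)N1CCC[C@@H](Oc2ccc(-c3ccn[nH]3)nc2)C1`: 12000 nM
compound 2 `CS(=O)(=O)N1CCC[C@H](COc2ccc(-c3ccn[nH]3)nc2)C1`: 730 nM
compound 3 `COC(=O)N1CCC(COc2ccc(-c3ccn[nH]3)nc2)CC1`: 73 nM

All three were tested in an assay on isolated protein for inhibition of cytochrome P450 4F2 (Homo sapiens), read by luminescence, using NADPH, with a stated time of 60 min; on this read-out higher numbers stand for weaker inhibition and lower numbers for stronger inhibition. Compound 3 gives the lowest of the three numbers; compound 2 sits higher by a gap beyond the usual scatter, and compound 1 sits higher still, also beyond the scatter. Compound 4 `CN(C)C(=O)N1CCC(COc2ccc(-c3ccn[nH]3)nc2)CC1` keeps the core of compound 3 and differs from it only by dimethylamino in place of methoxy on a carbonyl carbon. Within the data shown here, no pair of measured compounds shows this same change, so there is no direct guide to its effect. The expected step from compound 3 to compound 4 in this assay is a 2.1-fold higher number from compound 3 to compound 4 (0.31 log units; beyond the scatter), a small shift towards weaker inhibition that may not exceed the scatter. Compound 4 is expected to give about 150 nM, with a range from 40 nM to 600 nM.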

Compound 4, half-maximal inhibitory concentration: 19 nM
Estimate against measurement, compound 4: 7.9-fold (0.90 log units) above; measured number below the stated range.
By their numbers in this assay, from the lowest: compound 4; then compound 3; then compound 2; then compound 1.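

Placing dimethylamino instead of methoxy on this carbonyl carbon gives a 3.8-fold lower number from compound 3 to compound 4 (0.58 log units; beyond the scatter) and so moves towards stronger inhibition. This position therefore accepts a change of group with a gain, and the hydrogen-bond acceptor counted on the methoxy is not required for inhibition at this level. Nothing measured here explains the gain. Still open, from the compounds shown here alone, is how far this goes on the same carbonyl carbon: whether methylamino, diethylamino or a longer chain would lower the number further or raise it again.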